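Sulfonyl substituent series: phenyl sulfone replacing tetrahydroisoquinoline

The source may hold more compounds than are shown below. What is called first, only, known or untested is meant among the compounds shown, and "the series" means these compounds.

Notes on variation at the sulfonyl sulfur of the shared core.

Compound 3 `O=C(NCc1ccncc1)Nc1ccc(S(=O)(=O)N2CCc3ccccc3C2)cc1` gives the lowest number of the three measured in an assay on isolated protein for activation of Nicotinamide phosphoribosyltransferase (Homo sapiens) (a lower number here means that less compound is needed, a higher number that more compound is needed for the effect), at 142 nM. Compound 1 `O=C(NCc1ccncc1)Nc1ccc(S(=O)(=O)N2CC3CCC(C2)O3)cc1` gives 279 nM in this assay, and the step of a 2.0-fold lower number from compound 1 to compound 3 (0.29 log units; within the scatter) lies within the scatter, so compound 3 and compound 1 cannot be ordered. Compound 2 `CNS(=O)(=O)c1ccc(NC(=O)NCc2ccncc2)cc1` gives 3230 nM, the highest number of the three; the steps of a 12-fold higher number from compound 1 to compound 2 (1.06 log units; beyond the scatter) and a 23-fold lower number from compound 2 to compound 3 (1.36 log units; beyond the scatter) are both large.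

Compound 4 `O=C(NCc1ccncc1)Nc1ccc(S(=O)(=O)c2ccccc2)cc1` differs from compound 3 by phenyl in place of 1,2,3,4-tetrahydroisoquinolin-2-yl on a sulfonyl sulfur. Going by the values given here, two measured steps bear on this. Replacing methylamino by a ring-bearing group on the sulfonyl sulfur gave a 23-fold lower number from compound 2 to compound 3 (1.36 log units; beyond the scatter), while exchanging one ring-bearing group for another gave a 2.0-fold lower number from compound 1 to compound 3 (0.29 log units; within the scatter). Among the compounds with values here, no measured step removes the nitrogen from the sulfonyl sulfur or reduces the group to a single ring. Phenyl keeps an aromatic ring, as the group of compound 3 does, but lacks the non-aromatic ring with its hetero atom, so a step toward higher numbers, beyond the scatter yet well short of the step to methylamino, is expected. For compound 4 the expected step is a 4.2-fold higher number from compound 3 to compound 4 (0.63 log units; beyond the scatter). Compound 4 is therefore estimated at 600 nM, with a range from 150 nM to 2500 nM.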

Compound 4, half-maximal effective concentration: 85 nM
Compound 4: middle estimate off by 7.1-fold (0.85 log units), on the high side; the whole stated range lies above it.
By their numbers in this assay, from the lowest: compounds 4, 3 and 1 (each within the scatter of the next, the first and the last beyond it); then compound 2.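

Phenyl in place of 1,2,3,4-tetrahydroisoquinolin-2-yl on a sulfonyl sulfur gives a 1.7-fold lower number from compound 3 to compound 4 (0.22 log units; within the scatter), so in this assay these two cannot be ordered, and neither a nitrogen on the sulfonyl sulfur nor a non-aromatic ring is required for a number at this level. Phenyl also stands well apart from methylamino, with a 38-fold lower number from compound 2 to compound 4 (1.58 log units; beyond the scatter), so this large gap, earlier seen only between sulfonyl-bound nitrogen groups, now also appears with a single aromatic ring and no nitrogen in the group. Going by these compounds alone, the step of a 3.3-fold lower number from compound 1 to compound 4 (0.52 log units; beyond the scatter) is modest, but it is the first step beyond the scatter between two ring-bearing groups at this place, whereas compound 3 remains within the scatter of both. Nothing at hand accounts for these steps.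

Still open, as far as these compounds go, is whether the aromatic ring itself carries the effect, which a cyclohexyl or a plain methyl on the sulfonyl sulfur would help to separate from ring size alone. Also open, from the compounds shown here alone, is how far the phenyl tolerates change, for example a pyridyl in its place or a fluorine or methoxy group on it.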